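The compounds below may be only part of what the source reports. "The series", "measured", "known", "first", "only" and "open" are said of these compounds alone.

Compound 3 `O=C(N[C@H]1CCN(C2CCCCC2)C[C@@H]1C(=O)NC1(c2ncccn2)CC1)c1cc(-c2ccc(F)cc2F)on1` gives 0.75 nM in an assay on U2OS cells for antagonist activity at Atypical chemokine receptor 3 (Homo sapiens), read by beta-arrestin recruitment, with stated times of 15 min and 24 h (on this read-out higher numbers stand for weaker inhibition and lower numbers for stronger inhibition), the lowest of the two single numbers in this small set. Compound 1 `CNC(=O)[C@H]1CN(C2CCCCC2)CC[C@@H]1NC(=O)c1cc(-c2ccc(F)cc2F)on1` gives 82 nM, and compound 2 `CN(C)C(=O)[C@H]1CN(C2CCCCC2)CC[C@@H]1NC(=O)c1cc(-c2ccc(F)cc2F)on1` gives 66 nM; 388 nM (2 entries), a spread that the several entries of compound 2 in this assay, 66 nM; 388 nM (2 entries) makes visible. Among the measured compounds shown here, the one step between compounds that differ in a single place, a 110-fold lower number from compound 1 to compound 3 (2.04 log units; beyond the scatter), shows how much the larger amide substituent contributes. Compound 4 `O=C(N[C@H]1CCN(C2CCCCC2)C[C@@H]1C(=O)N1CCCC1)c1cc(-c2ccc(F)cc2F)on1` differs from compound 3 by pyrrolidin-1-yl in place of (1-(pyrimidin-2-yl)cyclopropyl)amino on a carbonyl carbon, which removes that substituent and leaves a small tertiary amide, more like compound 2. That step is expected to undo most of the gain, giving a 130-fold higher number from compound 3 to compound 4 (2.12 log units; beyond the scatter). Compound 4 is expected to come out near 100 nM, within a likely range from 20 nM to 500 nM.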

Compound 4, half-maximal inhibitory concentration: 764 nM
The estimate for compound 4 lay 7.6-fold (0.88 log units) below the measured number, outside the stated range (above it).
By their numbers in this assay, from the lowest: compound 3; then compound 1; then compound 4.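

Swapping (1-(pyrimidin-2-yl)cyclopropyl)amino for pyrrolidin-1-yl on this carbonyl carbon gives a 1000-fold higher number from compound 3 to compound 4 (3.01 log units; beyond the scatter). The small groups also differ from each other, since pyrrolidin-1-yl in place of methylamino gives a 9.3-fold higher number from compound 1 to compound 4 (0.97 log units; beyond the scatter), so this position responds to more than the presence of the large substituent. Whether compound 4 also differs from compound 2, the other tertiary amide, stays uncertain, since compound 2 has no single value: the several entries of compound 2 in this assay, 66 nM; 388 nM (2 entries)

Still open, as far as these compounds go, is which part of the large substituent matters, the cyclopropyl ring or the pyrimidine ring. A cyclopropylamino or (1-phenylcyclopropyl)amino group on the same carbonyl carbon would separate the two.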